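Fluoro for trifluoromethyl: expecting a small shift

The source may hold more compounds than are shown below. What is called first, only, known or untested is meant among the compounds shown, and "the series" means these compounds.

Three compounds have been measured in a functional assay on LNCaP cells (Homo sapiens) for cytotoxicity, read by MTT assay, with a stated time of 72 h; a higher number here means a weaker inhibitor, a lower number a stronger inhibitor:
compound 1 `COc1ccc(/C=C/C(=O)/C=C/C2=C(C)CCCC2(C)C)cc1OC` gives 9500 nM;
compound 2 `CC1=CCCC(C)(C)C1/C=C/C(=O)/C=C/c1ccc(C(F)(F)F)cc1` gives 4700 nM;
compound 3 `CC1=C(/C=C/C(=O)/C=C/c2ccc(C(F)(F)F)cc2)C(C)(C)CCC1O` gives 3000 nM.

Compound 3 has the lowest of the three numbers. Its nearest neighbour is compound 2, whose number lies within the usual scatter, so the two cannot be told apart. Compound 1 lies furthest away, beyond the scatter, so compound 3 is the stronger inhibitor of that pair in this assay.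

Compound 4 `CC1=C(/C=C/C(=O)/C=C/c2ccc(F)cc2)C(C)(C)CCC1O` differs from compound 3 in one place: fluoro in place of trifluoromethyl on an aromatic carbon. Among the measured compounds shown here, no measured pair shows this kind of change, so nothing here tells its size. A small step is expected, if anything towards a weaker inhibitor, and probably not beyond the scatter. Compound 4 is estimated at 4500 nM, with a range of 1500 nM to 14000 nM, meaning an expected step from compound 3 to compound 4 of a 1.5-fold higher number from compound 3 to compound 4 (0.18 log units; within the scatter) in this assay.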

Compound 4, half-maximal inhibitory concentration: 3900 nM
Beside the measured number, compound 4's estimate is 1.2-fold (0.06 log units) above it, within the range that was stated.
By their numbers in this assay, from the lowest: compounds 3, 4 and 2 (each within the scatter of the next); then compound 1.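

In this assay, putting fluoro in place of trifluoromethyl on this aromatic carbon gives a 1.3-fold higher number from compound 3 to compound 4 (0.11 log units; within the scatter) and so leaves the two compounds indistinguishable. This first single-change pair shows that fluoro, with 1 heavy atom, can stand in for trifluoromethyl, with 4, without a readable change in the number. Nothing available explains this result.

Going by these compounds, whether a different group here, such as an amine, a carboxylic acid or a longer carbon chain, would move the number remains open. So does whether the same swap would behave alike on the core of compound 2.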